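A few compounds are considered here, and "the series" means these few. Any claim that something is new, unique, unknown or untested is made for them only; others in the source may bear on it.

Two members of the series have numbers in a functional assay on U-87MG ATCC cells (Homo sapiens) for antiproliferative activity, read by MTT assay, with a stated time of 48 h (a higher number here means a weaker inhibitor, a lower number a stronger inhibitor), so far. Compound 1 `COc1cc(N/C=C\C(=O)c2cn(-c3ccccc3)nc2-c2ccc(F)cc2)cc(OC)c1OC` gives 12600 nM in this assay. Compound 2 `COc1cc(-c2nn(-c3ccccc3)cc2C(=O)/C=C\Nc2ccc(O)cc2)cc(OC)c1OC` gives 1800 nM in this assay, the lowest of the two numbers; compound 1, its nearest neighbour, stands at a markedly higher number, and the gap between the two is beyond the usual scatter. For the measured compounds named here, the two compounds differ in more than one place, so no single step between them can be read.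

Compound 3 `COc1cc(N/C=C\C(=O)c2cn(-c3ccccc3)nc2-c2cc(OC)c(OC)c(OC)c2)cc(OC)c1OC` has not yet been measured in this assay. It differs from compound 2 in one place: 3,4,5-trimethoxyphenyl in place of 4-hydroxyphenyl on an amine nitrogen. Going by the values given here, no measured step shows this change on its own. The expectation for the step from compound 2 to compound 3 is a 3.3-fold higher number from compound 2 to compound 3 (0.52 log units; beyond the scatter), towards a higher number, beyond the scatter but smaller than the gap to compound 1. Compound 3 is therefore estimated at 6000 nM in this assay, within a range of 2000 nM to 20000 nM.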

Compound 3, half-maximal inhibitory concentration: 5100 nM
The estimate for compound 3 lay 1.2-fold (0.07 log units) above the measured number; the range from low to high includes it.
By their numbers in this assay, from the lowest: compound 2; then compound 3; then compound 1.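

In this assay, the amine nitrogen can now be read on its own: with 3,4,5-trimethoxyphenyl on the aromatic carbon in both compounds, 3,4,5-trimethoxyphenyl in place of 4-hydroxyphenyl on the amine nitrogen gives a 2.8-fold higher number from compound 2 to compound 3 (0.45 log units; beyond the scatter), so here the 4-hydroxyphenyl group goes with the lower number. The aromatic carbon can also be read: with 3,4,5-trimethoxyphenyl on the amine nitrogen in both compounds, 3,4,5-trimethoxyphenyl in place of 4-fluorophenyl gives a 2.5-fold lower number from compound 1 to compound 3 (0.39 log units; beyond the scatter), a modest step in the opposite direction. Nothing to hand accounts for either step.

For the compounds shown here, whether the two changes would hold with other partners remains open, as 4-hydroxyphenyl on the amine nitrogen is seen only with 3,4,5-trimethoxyphenyl on the aromatic carbon. A 4-methoxyphenyl or 4-aminophenyl group on the amine nitrogen would show how far the step extends beyond these two groups.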